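The source may report more compounds than this note shows. Statements on the series, on what has been measured and on what is new or still open speak of the compounds shown alone.

In a functional assay on HeLa cells (Homo sapiens) for antiproliferative activity, read by MTT assay, with a stated time of 48 h (a higher number here means a weaker inhibitor, a lower number a stronger inhibitor), three compounds sharing one core have been read so far, and only compound 3 (`CN(C)CCCn1c(N)c(-c2nc3ccccc3[nH]2)c2nc(C#N)c(C#N)nc21`) returns an actual number: compound 3 gives 25900 nM. Compound 1 (`CN1CCN(CCn2c(N)c(-c3nc4ccccc4[nH]3)c3nc(C#N)c(C#N)nc32)CC1`) gives > 50000 nM, which is a limit of the assay and not a number. Compound 2 (`CCCn1c(N)c(-c2nc3ccccc3[nH]2)c2nc(C#N)c(C#N)nc21`) gives > 50000 nM, again a limit and not a number.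

The next compound, compound 4 (`CCN(CC)CCCCn1c(N)c(-c2nc3ccccc3[nH]2)c2nc(C#N)c(C#N)nc21`), carries a change on the side chain: (diethylamino)methyl in place of dimethylamino on a saturated chain carbon, three bonds along the chain from an aromatic nitrogen. Cut one bond further out, this reads as 3-(dimethylamino)propyl to 4-(diethylamino)butyl.

Among the measured compounds shown here, three measured steps touch this chain, and all are hard to size because of the limit of > 50000 nM in this assay, at which 2 of the 3 values shown sit. The closest is an at least 1.9-fold lower number from compound 2 to compound 3 (0.28 log units; that floor lies within the scatter). Next comes an at least 1.9-fold lower number from compound 1 to compound 3 (0.28 log units; that floor lies within the scatter), whose floor also lies within the scatter, and the last is a step that the two limits leave unreadable from compound 1 to compound 2. None of them is shown to go beyond the scatter, so with an at least 1.9-fold lower number from compound 2 to compound 3 (0.28 log units; that floor lies within the scatter) as the main guide, no step beyond the scatter is expected in this assay, in either direction.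

The expected change is a 1.2-fold lower number from compound 3 to compound 4 (0.07 log units; within the scatter). Compound 4 is estimated at 22000 nM, with an expected range from 7000 nM to 50000 nM.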

Compound 4, half-maximal inhibitory concentration: 10100 nM
Compound 4: middle estimate off by 2.2-fold (0.34 log units), on the high side; low and high end bracket the measured number.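

In this assay, among the compounds shown here, the change from 3-(dimethylamino)propyl to 4-(diethylamino)butyl gives a 2.6-fold lower number from compound 3 to compound 4 (0.41 log units; beyond the scatter), the first step on this side chain that is measured between two actual numbers and lies beyond the scatter. Two further steps now also clear the scatter, an at least 4.9-fold lower number from compound 2 to compound 4 (0.69 log units; beyond the scatter) and an at least 4.9-fold lower number from compound 1 to compound 4 (0.69 log units; beyond the scatter), so the 4-(diethylamino)butyl chain is set apart from both the propyl chain of compound 2 and the 4-methylpiperazin-1-yl chain of compound 1. These two steps are floors, and their full size cannot be read because of this limit: the limit of > 50000 nM in this assay, at which 2 of the 4 values shown sit.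

The change to compound 4 alters the chain length and the groups on the amine together, and the compounds shown do not separate the two, which a 3-(diethylamino)propyl or a 4-(dimethylamino)butyl chain would do. From the compounds shown here alone, it also remains open whether the number keeps falling with a longer chain such as 5-(diethylamino)pentyl, or how a pyrrolidine or a morpholine at the chain end would read.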